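Replacing the diol of compound 1 with a stereodefined propyl chain

A few compounds are considered here, and "the series" means these few. Any claim that something is new, unique, unknown or untested is made for them only; others in the source may bear on it.

In a functional assay on the whole organism (spleen, spleen) with Rattus norvegicus as the target (on this read-out lower numbers stand for an effect already at smaller amounts and higher numbers for an effect only at larger amounts of compound), compound 1 `CCCCCCCOc1ccc(CCC(N)(CO)CO)cc1` gives 0.049 mg/kg, the lowest of the two numbers measured here. Compound 3 `CCCCCCCOc1ccc(CCC(N)(CO)CCC)cc1` gives 3.1 mg/kg in this assay. For compound 2 `CCCCCCCCc1ccc(CCC(N)(CO)C(=O)O)cc1` this assay reports only a limit, > 10 mg/kg, not a number. Compound 4 `CCCCCCCOc1ccc(CC[C@@](N)(CO)CCC)cc1` has not yet been measured in this assay. It differs from compound 1 by a group of 7 heavy atoms (5 carbon, 1 nitrogen, 1 oxygen; no ring) in place of a group of 6 heavy atoms (3 carbon, 1 nitrogen, 2 oxygen; no ring), on a saturated chain carbon, two bonds along the chain from an aromatic carbon; the group that enters carries one defined stereocentre.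

Among the measured compounds shown here, the one measured step that bears on this change is a 63-fold higher number from compound 1 to compound 3 (1.80 log units; beyond the scatter), where the same kind of exchange was made without a defined stereocentre. Compound 4 is therefore expected to sit far higher than compound 1 in this assay, the step being estimated as a 41-fold higher number from compound 1 to compound 4 (1.61 log units; beyond the scatter). The estimate for compound 4 in this assay is 2 mg/kg, with a likely range from 0.5 mg/kg to 10 mg/kg; the defined stereocentre may move the number to either side of compound 3.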

Compound 4, dose for 50% inhibition: 0.63 mg/kg
Compound 4: the middle estimate sits 3.2-fold (0.50 log units) above what was measured; low and high end bracket the measured number.
By their numbers in this assay, from the lowest: compound 1; then compound 4; then compound 3. At a limit, above all of these: compound 2.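

At this saturated chain carbon, configuration counts: this assay records a 4.9-fold lower number from compound 3 to compound 4 (0.69 log units; beyond the scatter). Among the compounds shown here, the only difference behind that step is how the stereocentre is drawn: the fact that one of compounds 3 and 4 is drawn with a defined configuration and the other without, at the place where they differ. Even with the R configuration in place, the exchange of the 1-amino-2-hydroxy-1-(hydroxymethyl)ethyl group still leaves a 13-fold higher number from compound 1 to compound 4 (1.11 log units; beyond the scatter), so a defined stereocentre narrows the gap to compound 1 but does not close it.

The compounds shown leave open what the S configuration at the same carbon would give, since no compound here carries it. From the compounds shown here alone, it also remains open whether an ethyl or a butyl chain in place of the propyl chain, or a second hydroxyl on that chain, would bring the number closer to that of compound 1.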